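Benzylamino variation on a shared ribosylated core: transporter inhibition

The compounds below may be only part of what the source reports. "The series", "measured", "known", "first", "only" and "open" are said of these compounds alone.

Measured so far:
compound 1 `Cc1ccccc1CNc1nc2c(N)ncnc2n1[C@@H]1O[C@H](CO)[C@@H](O)[C@H]1O` gives 65000 nM in an assay on COS-7 cells for inhibition of sodium/nucleoside cotransporter 2 (Homo sapiens), read by scintillation counting, in the presence of a further agent that is not named here; on this read-out higher numbers stand for weaker inhibition and lower numbers for stronger inhibition
compound 2 `Cc1cccc(CNc2nc3c(N)ncnc3n2[C@@H]2O[C@H](CO)[C@@H](O)[C@H]2O)c1` gives 19000 nM
compound 3 `COc1cccc(CNc2nc3c(N)ncnc3n2[C@@H]2O[C@H](CO)[C@@H](O)[C@H]2O)c1` gives 13000 nM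

Compound 3 carries the lowest number of the three; its gap to compound 2 lies within the scatter, its gap to compound 1 beyond it. Compound 4 `Nc1ncnc2c1nc(NCc1cccc(-c3ccccc3)c1)n2[C@@H]1O[C@H](CO)[C@@H](O)[C@H]1O` differs from compound 3 by phenyl in place of methoxy on an aromatic carbon. Among the measured compounds shown here, no measured step exchanges a methoxy for a phenyl. The step that comes nearest is a 1.5-fold lower number from compound 2 to compound 3 (0.16 log units; within the scatter), an exchange on the same aromatic carbon that stayed within the scatter; a 3.4-fold lower number from compound 1 to compound 2 (0.53 log units; beyond the scatter) and a 5.0-fold lower number from compound 1 to compound 3 (0.70 log units; beyond the scatter) moved the group around the ring and were modest. The direction for a phenyl is therefore open and no step beyond the scatter is firmly expected. For compound 4 in this assay the expected step is a 1.3-fold lower number from compound 3 to compound 4 (0.11 log units; within the scatter), an estimated 10000 nM within 2500 nM to 40000 nM.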

Compound 4, half-maximal inhibitory concentration: 21000 nM
Estimate against measurement, compound 4: 2.1-fold (0.32 log units) below; the measured number falls inside the stated range.
By their numbers in this assay, from the lowest: compounds 3, 2 and 4 (each within the scatter of the next); then compound 1.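

On this aromatic carbon, meta to a large group, phenyl brings a whole six-membered aromatic ring, yet in this assay the number stays within the scatter of the smaller groups (a 1.6-fold higher number from compound 3 to compound 4 (0.21 log units; within the scatter); a 1.1-fold higher number from compound 2 to compound 4 (0.04 log units; within the scatter)). Methyl, methoxy and phenyl at this place therefore cannot be told apart, which extends the range of groups held here well beyond the small ones seen earlier. Nothing available explains this insensitivity to group size. On these data alone, whether an amine or a carboxylic acid on this carbon would shift the number beyond the scatter remains open. So does the effect of a longer chain between the nitrogen and the aromatic ring.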